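Cytotoxicity notes: pyrrolidinone replacing indolyl on the shared core

The source may report more compounds than this note shows. Statements on the series, on what has been measured and on what is new or still open speak of the compounds shown alone.

Measured compounds in an ADME assay on HEL cells (Homo sapiens) for cytotoxicity, with a stated time of 3 days; on this read-out lower numbers stand for higher toxicity in this test and higher numbers for lower toxicity in this test:
compound 1 `C=Cc1ccc(-c2cc(C)c3ncc(CSCc4ccccc4)n3c2)cc1` gives >= 100 ug/mL, a limit of the test
compound 2 `Cc1cc(-c2ccc3[nH]ccc3c2)cn2c(CSCCc3ccccc3)cnc12` gives >= 20 ug/mL, a limit of the test
compound 3 `Cc1cc(-c2ccsc2)cn2c(CSCc3ccccc3)cnc12` gives 4 ug/mL, a number

Compound 2 stands only as a limit in this assay; one further value, that of compound 1, is likewise a limit, so only compound 3 carries a number. Among the compounds with values here, the single step computed among the measured compounds is an at least 25-fold lower number from compound 1 to compound 3 (1.39 log units; beyond the scatter), which exchanges one aromatic group for another on the core of compound 1 and carries the shorter linker.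

Compound 4 `Cc1cc(N2CCCC2=O)cn2c(CSCCc3ccccc3)cnc12` differs from compound 2 by 2-oxopyrrolidin-1-yl in place of 1H-indol-5-yl on an aromatic carbon. Within the data shown here, no measured step exchanges an aromatic group for a non-aromatic ring, and no measured pair shares the longer linker of compound 2 with a second partner, so the one step available does not bear directly on this change. The limit of compound 2 and the limit of compound 1 show that this core with a benzyl or phenethyl thioether chain is compatible with low toxicity; compound 3 shows that a change of the aromatic group alone can move the read-out far.

Compound 4 is therefore expected to stay near the limit region, with a step that the limit leaves unreadable from compound 2 to compound 4, giving an estimate of 50 ug/mL, ranging from 20 ug/mL to 100 ug/mL.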

Compound 4, minimum cytotoxic concentration: > 100 ug/mL
Compound 4 ended at the assay's limit; the forecaster's own chance of this, stated with the estimate: 70%; at least 2.0-fold (0.30 log units) between middle value and limit.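

In this assay compound 4 gives > 100 ug/mL, a limit of the test. Within the data shown here, compound 2 gives >= 20 ug/mL, also a limit, so no step from compound 2 to compound 4 can be read. The compounds shown leave open how far 2-oxopyrrolidin-1-yl and 1H-indol-5-yl differ on this read-out with the chain of compound 2.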